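Replacing a Urea Carbamoyl Group on a Bicyclic Nucleoside

This account rests on a few compounds, and the source may have more. Where it says the series, first, only, none or still open, it means among the compounds named here.

Of the compounds shown here, three have been measured in a functional assay on HEL cells (Homo sapiens) for cytotoxicity, read by microscopy; a higher number here means that more compound is tolerated, a lower number that less compound is tolerated. Compound 1 `CCNC(=O)NC1=CS(=O)(=O)O[C@@]12[C@@H](CO[Si](C)(C)C(C)(C)C)O[C@@H](n1cc(C)c(=O)n(C)c1=O)[C@@H]2O[Si](C)(C)C(C)(C)C` gives >= 3200 nM, which is a limit of the assay rather than a number. Compound 3 `Cc1cn([C@@H]2O[C@@H]3COC(=O)[C@]3(OS(C)(=O)=O)[C@H]2O)c(=O)[nH]c1=O` gives >= 400000 nM, again a limit of the assay. Among the measured compounds shown here, compound 2 `Cc1cn([C@@H]2O[C@H](CO[Si](C)(C)C(C)(C)C)[C@@]3(OS(=O)(=O)C=C3NC(N)=O)[C@H]2O[Si](C)(C)C(C)(C)C)c(=O)n(C)c1=O` is the only one that gives a number, 16000 nM in this assay. The step that the limit leaves unreadable from compound 1 to compound 2 cannot be sized because of the limit of >= 3200 nM in this assay, at which 1 of the 3 values shown sits, so it shows nothing about how the ethyl-to-hydrogen exchange moves the read-out.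

Compound 4 `Cc1cn([C@@H]2O[C@H](CO[Si](C)(C)C(C)(C)C)[C@@]3(OS(=O)(=O)C=C3NCC(=O)C(=O)N3CCC3)[C@H]2O[Si](C)(C)C(C)(C)C)c(=O)n(C)c1=O` is not yet measured. It differs from compound 2 by (((azetidin-1-yl)carbonyl)carbonyl)methyl in place of carbamoyl on an amine nitrogen. For the measured compounds named here, no measured step bears on this kind of change: the only step that touches the same nitrogen is unreadable, and compound 3 has a different core with no urea. Without a readable step, no direction beyond the scatter can be expected, and the two limits in the limit of >= 3200 nM in this assay, at which 1 of the 3 values shown sits, and the limit of >= 400000 nM in this assay, at which 1 of the 3 values shown sits, warn that a limit is a likely outcome again. Compound 4 is therefore estimated to give about 16000 nM in this assay, within 4000 nM to 64000 nM, an expected step of no change at the digits printed from compound 2 to compound 4 (within the scatter) from compound 2.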

Compound 4, minimum cytotoxic concentration: 65000 nM
The estimate for compound 4 lay 4.1-fold (0.61 log units) below the measured number; the measured number lies above the stated range.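

In this assay, among the compounds shown here, the exchange at this amine nitrogen gives the first readable step here: a 4.1-fold higher number from compound 2 to compound 4 (0.61 log units; beyond the scatter). Ureido can thus give way to ((((azetidin-1-yl)carbonyl)carbonyl)methyl)amino, with a larger group that has one four-membered ring and no hydrogen-bond donor, and the read-out moves beyond the scatter towards more compound tolerated. The steps that start from compound 1 cannot be read, since compound 1 sits at a limit: the limit of >= 3200 nM in this assay, at which 1 of the 4 values shown sits.

This single step does not separate the share of the azetidine ring from that of the two carbonyl groups, or from the loss of the urea itself. From the compounds shown here alone, it remains open whether a pyrrolidine or a plain dimethylamine in place of the azetidine, or a simple methyl on this nitrogen, would move the read-out the same way.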